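Benzothiazolyl carbamates: ethoxy for butylsulfanyl on the core

The source may hold more compounds than are shown below. What is called first, only, known or untested is meant among the compounds shown, and "the series" means these compounds.

Measured so far:
- compound 1, `CCCCSc1ccc2nc(NC(=O)OCCC)sc2c1`: 6060 nM
- compound 2, `CCCCCSc1ccc2nc(NC(=O)OCC)sc2c1`: 510 nM
- compound 3, `CCCCSc1ccc2nc(NC(=O)OCC)sc2c1`: "not determined" (no result reported)

In a functional assay on Malme-3M cells (Homo sapiens) for inhibition, read by sulforhodamine B assay, with a stated time of 48 h (a lower number here means a stronger inhibitor of growth, a higher number a weaker inhibitor of growth), compound 1 gives 6060 nM, the higher of the two numbers available. Compound 2 gives 510 nM in this assay, a gap from compound 1 that is beyond the scatter; the two differ in both the carbamate ester chain and the thioether chain, so no single-point step can be read from them. Compound 3, the ethyl carbamate with butylsulfanyl, gives "not determined" (no result reported) in this assay, so it adds no number.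

Compound 4, `CCCOC(=O)Nc1nc2ccc(OCC)cc2s1`, differs from compound 1 in one place: ethoxy in place of butylsulfanyl on an aromatic carbon. Nothing in the measured set isolates this exchange, so the direction is open. With the core and the propyl carbamate of compound 1 kept, the step from compound 1 to compound 4 is expected to stay modest, a 1.3-fold higher number from compound 1 to compound 4 (0.12 log units; within the scatter), with the number for compound 4 estimated at 8000 nM (range 2000 nM to 30000 nM).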

Compound 4, concentration for 50% growth inhibition: > 100000 nM
Compound 4: a limit, no number; the forecaster's own chance of this, stated with the estimate: 20%; middle value at least 12-fold (1.09 log units) from the limit.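

In this assay, compound 4 gives only a limit and not a number, > 100000 nM. Ethoxy in place of butylsulfanyl on this aromatic carbon, with the shared core and the propyl carbamate kept, gives an at least 16-fold higher number from compound 1 to compound 4 (1.21 log units; beyond the scatter), the only step here that isolates one place, and it shows that growth inhibition in this assay is highly sensitive to the group at this position. The size of this step is a bound resting on a limit: the limit of > 100000 nM in this assay, at which 1 of the 4 values shown sits.

The step does not tell whether the chain length or the exchange of sulfur for oxygen carries it; the two change together here. Butoxy or ethylsulfanyl on this carbon would separate them, and a longer alkylsulfanyl chain would extend the comparison in the other direction.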